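Removing the trifluoromethyl from the pyridine of compound 3

The compounds below may be only part of what the source reports. "The series", "measured", "known", "first", "only" and "open" are said of these compounds alone.

The series shares one bicyclic amine core carrying an aromatic six-membered ring with one nitrogen. Compound 1 `Fc1ccc(C2=CC3CNCC(C2)C3)cn1` carries a fluorine on that ring, compound 2 `Clc1ccccc1Oc1cncc(C2=CC3CNCC(C2)C3)c1` an aryloxy group, compound 3 `FC(F)(F)c1cncc(C2=CC3CNCC(C2)C3)c1` a trifluoromethyl. In an in vitro assay on SH-SY5Y cells for displacement of a labelled ligand from Neuronal acetylcholine receptor; alpha3/beta4 (Homo sapiens) (a lower number here means a stronger inhibitor, a higher number a weaker inhibitor), compound 1 gives 28 nM and compound 2 gives 26 nM; those two values lie within the scatter of each other. Compound 3 gives 79 nM, the highest of the three numbers, and its gap to compound 1 and to compound 2 is beyond the scatter.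

Compound 4 `C1=C(c2cccnc2)CC2CNCC1C2` is the unsubstituted parent: hydrogen in place of trifluoromethyl on an aromatic carbon. For the measured compounds named here, no pair of measured compounds differs by this exact change, so the expectation rests on the spread above. Because compound 1 gives 28 nM and compound 2 gives 26 nM with other groups on the same ring, compound 4 is expected to return to that region, a step of a 2.3-fold lower number from compound 3 to compound 4 (0.35 log units; beyond the scatter) toward a lower number. Compound 4 is estimated at 35 nM, within 12 nM to 100 nM.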

Compound 4, inhibition constant: 12 nM
Compound 4: the middle estimate sits 2.9-fold (0.46 log units) above what was measured, and the stated range covers the measured number.
By their numbers in this assay, from the lowest: compound 4; then compounds 2 and 1 (each within the scatter of the next); then compound 3.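

For the compounds shown here, putting hydrogen in place of trifluoromethyl on this aromatic carbon, two atoms from the ring nitrogen, gives a 6.6-fold lower number from compound 3 to compound 4 (0.82 log units; beyond the scatter) in this assay and is the first direct reading of this change on the shared core. Hydrogen in place of fluoro on an aromatic carbon of the same ring also moves the number down, with a 2.3-fold lower number from compound 1 to compound 4 (0.37 log units; beyond the scatter) in this assay as well, so neither group that pairs directly with the unsubstituted compound 4 improves on hydrogen in this assay. No measurement shown here accounts for either step.

Still open, going by these compounds, is whether any group on the carbon that carries trifluoromethyl in compound 3 can improve on hydrogen, and an amine, a methoxy group or a nitrile there would test that. On these data alone, it is also open whether fluoro would read the same on that carbon as it does in compound 1.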